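The source may hold more compounds than are shown below. What is called first, only, known or untested is meant among the compounds shown, and "the series" means these compounds.

Measured so far in a functional assay on V79 cells (Cricetulus griseus) for cytotoxicity, read by colony formation; on this read-out lower numbers stand for stronger inhibition and higher numbers for weaker inhibition:
- compound 1 `NCC1CCN(c2c(F)cc3c(=O)c(C(=O)O)cn(C4CC4)c3c2Cl)C1`: 8 ug/mL
- compound 2 `CNCC1(C)CCN(c2c(F)cc3c(=O)c(C(=O)O)cn(C4CC4)c3c2Cl)C1`: 23 ug/mL

Of these two, compound 2 has the higher number, 23 ug/mL, so it is the weaker inhibitor in this assay. Compound 3 `O=C(O)c1cn(C2CC2)c2c(Cl)c(N3CCNCC3)c(F)cc2c1=O` is the next to be read. It carries piperazin-1-yl in place of 3-methyl-3-((methylamino)methyl)pyrrolidin-1-yl on an aromatic carbon, ortho to a chloro group and ortho to a fluoro group: piperazin-1-yl in place of 3-methyl-3-((methylamino)methyl)pyrrolidin-1-yl on an aromatic carbon.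

For the measured compounds named here, only one measured step bears on this change: a 2.9-fold higher number from compound 1 to compound 2 (0.46 log units; beyond the scatter). It is modest, and it involves the same attachment point. It does not involve piperazin-1-yl, so it gives a rough size for a change at this carbon but no firm direction. A step of similar or smaller size is therefore expected, with only a slight lean towards a higher number. The expected step is a 1.3-fold higher number from compound 2 to compound 3 (0.12 log units; within the scatter). For compound 3 the estimated value in this assay is 30 ug/mL, with an expected range of 10 ug/mL to 90 ug/mL.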

Compound 3, half-maximal inhibitory concentration: 43 ug/mL
Estimate against measurement, compound 3: 1.4-fold (0.16 log units) below, within the range that was stated.
By their numbers in this assay, from the lowest: compound 1; then compounds 2 and 3 (each within the scatter of the next).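

Notes on the aromatic carbon ortho to a chloro group and ortho to a fluoro group: in this assay the exchange of 3-methyl-3-((methylamino)methyl)pyrrolidin-1-yl for piperazin-1-yl gives a 1.9-fold higher number from compound 2 to compound 3 (0.27 log units; within the scatter), so this change of ring and substituent does not clearly separate the two groups. The wider comparison gives a 5.4-fold higher number from compound 1 to compound 3 (0.73 log units; beyond the scatter), and together with a 2.9-fold higher number from compound 1 to compound 2 (0.46 log units; beyond the scatter) it sets 3-(aminomethyl)pyrrolidin-1-yl apart from both other groups as the one with the lowest number among these three compounds. Nothing available explains these differences.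

The compounds shown leave open whether the lower number of compound 1 goes with its unsubstituted aminomethyl side chain or with the five-membered ring, since the step to compound 2 adds both a ring methyl and a methyl on the side-chain amine. A 3-aminopyrrolidin-1-yl group, or a 4-methylpiperazin-1-yl group at the same carbon, would help separate ring type from amine substitution in this assay.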